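The source may report more compounds than this note shows. Statements on the series, on what has been measured and on what is new or still open speak of the compounds shown alone.

In a functional assay on HeLa cells (Homo sapiens) for cytotoxicity, read by MTT assay, with a stated time of 2 days, tested at 10 uM (a higher number here means a weaker effect of the compound at the concentration tested, a lower number a stronger effect), compound 1 `CC(=O)c1cc(-c2ccc(F)cc2)cc2cc(-c3ccccc3)[nH]c12` gives 55.7%, the highest of the three numbers in hand, though the gaps to its companions stay within the scatter: compound 2 `CC(=O)c1cc(-c2ccc(F)cc2)cc2cc(-c3ccc(F)cc3)[nH]c12` gives 47.4% and compound 3 `COc1ccc(-c2cc3cc(-c4ccc(F)cc4)cc(C(C)=O)c3[nH]2)cc1` gives 52%. Compound 4 `CC(=O)c1cc(/C=C/c2ccccc2)cc2cc(-c3ccccc3)[nH]c12` has not been measured. It differs from compound 1 in one place: 2-phenylethenyl in place of 4-fluorophenyl on an aromatic carbon. The measured steps alter a different ring of the shared core, by a number 8.3 percentage points lower from compound 1 to compound 2 (within the scatter), by a number 3.7 percentage points lower from compound 1 to compound 3 (within the scatter) and by a number 4.6 percentage points higher from compound 2 to compound 3 (within the scatter), all within the scatter. Among the compounds with values here, no measured step touches the place changed here, so the expectation rests only on how quiet this small set is. A step within the scatter is expected in this assay, a number 2.7 percentage points lower from compound 1 to compound 4 (within the scatter). Compound 4 is therefore estimated at 53%, within 33% to 73%.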

Compound 4, a percentage reported as activity, at one concentration (the size of the read-out at that concentration, not a potency): 52.5%
Compound 4: middle estimate off by 0.5 percentage points, on the high side; measured number inside the range.
By their numbers in this assay, from the lowest: compounds 2, 3, 4 and 1 (each within the scatter of the next).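

Within the data shown here, this is the first change at this position, on the aromatic carbon meta to the acetyl group. In this assay, 2-phenylethenyl in place of 4-fluorophenyl gives a step of a number 3.2 percentage points lower from compound 1 to compound 4 (within the scatter), so this larger group, with its double bond outside the aromatic rings, separates from the fluorinated ring by no more than the scatter. Nothing available explains this similarity.

On these data alone, both groups at this position carry a six-membered aromatic ring of carbon only, so what an amine or a carboxylic acid would give there stays open. A reading at one concentration also leaves the potency of these compounds open.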